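The source may report more compounds than this note shows. Statements on the series, on what has been measured and on what is new or still open speak of the compounds shown alone.

In a functional assay on A549 cells (Homo sapiens) for inhibition, read by MTT assay, with a stated time of 48 h (on this read-out higher numbers stand for weaker inhibition and lower numbers for stronger inhibition), compound 1 `COc1ccc(/C=C/c2cc(OC)cc(OC)c2/C=C/C(=O)NC2CC2)cc1` gives 8810 nM, compound 2 `CCC(C)NC(=O)/C=C/c1c(/C=C/c2ccc(OC)cc2)cc(OC)cc1OC` gives 3950 nM and compound 3 `COc1ccc(/C=C/c2cc(OC)cc(OC)c2/C=C/C(=O)NC(C)C)cc1` gives 2360 nM. Compound 3 shares the low end of this short range with compound 2: the step of a 1.7-fold lower number from compound 2 to compound 3 (0.22 log units; within the scatter) stays within the scatter, while a 2.2-fold lower number from compound 1 to compound 2 (0.35 log units; beyond the scatter) and a 3.7-fold lower number from compound 1 to compound 3 (0.57 log units; beyond the scatter) are modest. Compound 4 `CCCCCCNC(=O)/C=C/c1c(/C=C/c2ccc(OC)cc2)cc(OC)cc1OC` carries hexyl in place of isopropyl on an amide-type nitrogen, that is, hexyl in place of isopropyl on an amide-type nitrogen. No hexyl amide has been measured, so these steps bear only loosely, but each is modest, the largest being a 3.7-fold lower number from compound 1 to compound 3 (0.57 log units; beyond the scatter). The expected step, a 1.5-fold higher number from compound 3 to compound 4 (0.17 log units; within the scatter), is small, towards a higher number and probably within the scatter. For compound 4 the estimated value is 3500 nM, with an expected range of 1300 nM to 9500 nM.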

Compound 4, half-maximal inhibitory concentration: 6230 nM
Compound 4: middle estimate off by 1.8-fold (0.25 log units), on the low side, within the range that was stated.
By their numbers in this assay, from the lowest: compounds 3, 2, 4 and 1 (each within the scatter of the next, the first and the last beyond it).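

Hexyl on the amide-type nitrogen gives up part of what isopropyl gave, with a 2.6-fold higher number from compound 3 to compound 4 (0.42 log units; beyond the scatter) beyond the scatter. The same group cannot be told apart from sec-butyl, with a 1.6-fold higher number from compound 2 to compound 4 (0.20 log units; within the scatter) within the scatter, or from cyclopropyl, with a 1.4-fold lower number from compound 1 to compound 4 (0.15 log units; within the scatter) also within it. Chain size alone therefore gives no clean order across these four amides, since cyclopropyl and hexyl stand together at the high end.

On these data alone, whether a chain longer than hexyl, or an amine or a carboxylic acid in place of hexyl on this nitrogen, would move the number stays open. No measured evidence accounts for these steps.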